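Removing the Trifluoromethyl Group from a Triazene Series

A few compounds are considered here, and "the series" means these few. Any claim that something is new, unique, unknown or untested is made for them only; others in the source may bear on it.

Compound 1, `CN(C)CCCN(/N=N/c1cc(F)ccc1F)c1cccc(C(F)(F)F)c1`: 30000 nM
Compound 2, `O=[N+]([O-])c1ccc(/N=N/N2CCCC2)cc1`: 90000 nM
Compound 3, `FC(F)(F)c1cccc(/N=N/c2ccc(NC[C@@H]3CCCN4CCCC[C@H]34)c3c2CCCC3)c1`: 50000 nM

The three compounds were examined in an ADME assay on Vero cells (Chlorocebus sabaeus) for cytotoxicity, read by crystal violet staining; on this read-out lower numbers stand for higher toxicity in this test and higher numbers for lower toxicity in this test. Compound 1 gives 30000 nM, the lowest of the three numbers. Its nearest neighbour is compound 3, which gives 50000 nM in this assay, a gap that falls within the usual scatter of repeated measurements, so the two cannot be ranked against each other. The furthest is compound 2, with 90000 nM in this assay, a gap that lies beyond the scatter.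

The step of interest leads from compound 1 to compound 4, `CN(C)CCCN(/N=N/c1cc(F)ccc1F)c1ccccc1`, which has not yet been measured in this assay. The two structures differ in one place: hydrogen in place of trifluoromethyl on an aromatic carbon. Among the measured compounds shown here, no pair of measured compounds shares this change, so its effect in this assay is unknown from the data at hand.

Given that the three measured numbers span only a modest range, compound 4 is expected to land close to compound 1. Compound 4 is estimated at 40000 nM, with a range from 15000 nM to 100000 nM. That estimate means a step of a 1.3-fold higher number from compound 1 to compound 4 (0.12 log units; within the scatter), expected to be toward a higher number but not beyond the scatter.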

Compound 4, half-maximal cytotoxic concentration: 7000 nM
Compound 4: the middle estimate sits 5.7-fold (0.76 log units) above what was measured; the whole stated range lies above it.
By their numbers in this assay, from the lowest: compound 4; then compounds 1, 3 and 2 (each within the scatter of the next, the first and the last beyond it).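

In this assay hydrogen in place of trifluoromethyl on an aromatic carbon gives a 4.3-fold lower number from compound 1 to compound 4 (0.63 log units; beyond the scatter) and so moves the read-out toward higher toxicity in this test. Among the compounds shown here, the earlier compounds offered no pair differing in one place, so this is the first reading of a single change, and it shows that this position, meta to a large group, is not indifferent here: the form carrying trifluoromethyl, compound 1, stands on the less toxic side of its hydrogen counterpart, compound 4. No measurement at hand bears on what lies behind this shift.

A single step at one position leaves open whether the effect belongs to trifluoromethyl itself or would follow from other groups on the same aromatic carbon, such as a chlorine atom, a methyl group or a nitrile. It also leaves open whether the same change would move the read-out in the same direction on a different core, such as that of compound 3, which also carries a trifluoromethyl group.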